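A few compounds are considered here, and "the series" means these few. Any claim that something is new, unique, unknown or untested is made for them only; others in the source may bear on it.

Of the compounds shown here, two have been measured in a functional assay on the whole organism with Mus musculus as the target; a higher number here means that more compound is needed for the effect, a lower number that less compound is needed. Compound 1 `CN(C)C(=O)Cn1c(-c2ccc(F)cc2)nc2cccnc21` gives 40.5 mg/kg, and compound 2 `CCCNC(=O)Cn1c(-c2ccc(Cl)cc2)nc2cccnc21` gives 37.5 mg/kg, which stands at the lower end of the two numbers, though the gap to compound 1 lies within the usual scatter. Compound 3 `CCOC(=O)CCCNC(=O)Cn1c(-c2ccc(Cl)cc2)nc2cccnc21` is compound 2 with one change: ethoxycarbonyl in place of hydrogen on a saturated chain carbon, three bonds along the chain from an amide-type nitrogen. Within the data shown here, no step between measured compounds is available to guide what this change does. In this assay the step is estimated as a 1.1-fold higher number from compound 2 to compound 3 (0.03 log units; within the scatter), meaning none beyond the scatter is expected. Compound 3 is therefore expected to give 40 mg/kg, within a range from 18 mg/kg to 90 mg/kg.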

Compound 3, dose for half-maximal effect: 100 mg/kg
The estimate for compound 3 lay 2.5-fold (0.40 log units) below the measured number, outside the stated range (above it).
By their numbers in this assay, from the lowest: compounds 2 and 1 (each within the scatter of the next); then compound 3.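

In this assay ethoxycarbonyl in place of hydrogen on a saturated chain carbon, three bonds along the chain from an amide-type nitrogen, gives a 2.7-fold higher number from compound 2 to compound 3 (0.43 log units; beyond the scatter) so more compound is needed for the effect. This shows that the far end of the propyl chain is not indifferent to change, since going from propyl to 3-(ethoxycarbonyl)propyl moves the number beyond the scatter. Nothing measured here explains this step. On these data alone, it remains open whether a carboxylic acid or an amine at the same place, or a longer chain without the ester, would shift the number as far.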